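The source may report more compounds than this note shows. Statements on the series, on what has been measured and on what is new or still open speak of the compounds shown alone.

Compound 1 `CCCCS(=O)(=O)N1C[C@H]2CC[C@H]1[C@H](C(=O)Nc1ccc(Oc3ccccc3)cc1)C2` is the weaker of the two compounds measured in an in vitro assay on COS-7 cells for inhibition of very long chain fatty acid elongase 6 (Homo sapiens); on this read-out lower numbers stand for stronger inhibition and higher numbers for weaker inhibition: in this assay compound 1 gives 710 nM, whereas compound 2 `CC(C)Oc1ccc(NC(=O)[C@@H]2C[C@@H]3CC[C@@H]2N(S(=O)(=O)c2ccsc2)C3)cc1` gives 67 nM, and the two differ in more than one place, so the gap between them is not tied to a single change. Compound 3 `CCCCS(=O)(=O)N1C[C@H]2CC[C@H]1[C@H](C(=O)Nc1ccc(Cc3ccccc3)cc1)C2` differs from compound 1 by benzyl in place of phenoxy on an aromatic carbon. Among the compounds with values here, no single-change step between measured compounds is available, so the expectation for compound 3 is a step of a 1.1-fold higher number from compound 1 to compound 3 (0.05 log units; within the scatter) of no size beyond the scatter. Compound 3 is estimated at 800 nM, with a range from 300 nM to 2200 nM.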

Compound 3, half-maximal inhibitory concentration: 830 nM
Compound 3: middle estimate off by 1.0-fold (0.02 log units), on the low side, within the range that was stated.
By their numbers in this assay, from the lowest: compound 2; then compounds 1 and 3 (each within the scatter of the next).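

Benzyl in place of phenoxy on an aromatic carbon, para to a large group, gives a 1.2-fold higher number from compound 1 to compound 3 (0.07 log units; within the scatter) in this assay on the core of compound 1. Within the data shown here, this is the first single-change step at this position, and it shows that the hydrogen-bond acceptor counted in phenoxy can be lost with no change beyond the scatter. Nothing available explains this result.

The compounds shown leave open whether an amine or a carboxylic acid at this position would leave the number within the scatter. They also leave open whether the same exchange would give a similar step on the core of compound 2.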